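The source may report more compounds than this note shows. Statements on the series, on what has been measured and on what is new or still open speak of the compounds shown alone.

Working notes on the series. Among the measured compounds shown here, compound 2 `Nc1scc(CN2CCN(c3ccc(F)c(F)c3)CC2)c1C(=O)c1ccc(Cl)cc1` is, in a functional assay on CHO cells with adenosine receptor A1 (Homo sapiens) as the target, read by cAMP accumulation and immunoassay, with a stated time of 6 min, tested at 10 uM (on this read-out lower numbers stand for a stronger effect and higher numbers for a weaker effect at the one concentration tested), the lowest of the two numbers so far, giving -87%; its nearest neighbour, compound 1 `Nc1scc(CN2CCN(c3ccc(Cl)cc3Cl)CC2)c1C(=O)c1ccc(Cl)cc1`, gives -74% in this assay. For the measured compounds named here, the one step available, a number 13 percentage points lower from compound 1 to compound 2 (beyond the scatter), came with the exchange of 2,4-dichlorophenyl for 3,4-difluorophenyl on the amine nitrogen in the ring, so halogen identity and placement moved together and no step isolates placement alone.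

Compound 3 `Nc1scc(CN2CCN(c3cc(F)ccc3F)CC2)c1C(=O)c1ccc(Cl)cc1` differs from compound 2 in this way: 2,5-difluorophenyl in place of 3,4-difluorophenyl on an amine nitrogen in a ring. Going by the values given here, the change keeps the same atoms and only rearranges the two fluorines on the phenyl ring on the amine nitrogen, a smaller alteration than the one step measured, which bears on it only loosely. On that basis the step for compound 3 is expected to be modest at most, with a number 7 percentage points higher from compound 2 to compound 3 (within the scatter) likely falling within the scatter. Compound 3 is estimated at -80% in this assay, with a range from -95% to -60%.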

Compound 3, a percentage reported as activity, at one concentration (the size of the read-out at that concentration, not a potency): -80%
Compound 3: the middle estimate sits on the measured number at the digits printed, within the range that was stated.
By their numbers in this assay, from the lowest: compounds 2, 3 and 1 (each within the scatter of the next, the first and the last beyond it).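

In this assay, rearranging the same two fluorines from 3,4-difluorophenyl to 2,5-difluorophenyl on the amine nitrogen in the ring gives a number 7 percentage points higher from compound 2 to compound 3 (within the scatter), so this position shows no readable effect of that rearrangement. Replacing 2,4-dichlorophenyl with 2,5-difluorophenyl gives a number 6 percentage points lower from compound 1 to compound 3 (within the scatter), whereas the exchange for 3,4-difluorophenyl gave a number 13 percentage points lower from compound 1 to compound 2 (beyond the scatter), so exchanging chlorine for fluorine does not by itself carry a step beyond the scatter. No measurement at hand offers an explanation for these steps.

Among the compounds shown here, no step here changes the halogen while holding its placement fixed, so the two remain tied together. Also open, from the compounds shown here alone, is how an unsubstituted phenyl, a methoxyphenyl or a cyanophenyl on the same nitrogen would read.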